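Double-bond geometry in the long chain

A few compounds are considered here, and "the series" means these few. Any claim that something is new, unique, unknown or untested is made for them only; others in the source may bear on it.

Values in a functional assay on cells (Homo sapiens) for cytotoxicity; a higher number here means a weaker inhibitor, a lower number a stronger inhibitor:
- compound 1 `CO/N=c1\[nH]cnc2c1[n+](Cc1ccccc1)cn2C`: > 80000 nM (a limit of the assay, not a number)
- compound 2 `CO/N=c1\[nH]cnc2c1[n+](C/C=C(\C)CCC=C(C)C)cn2C`: 18400 nM
- compound 3 `CO/N=c1\[nH]cnc2c1[n+](C/C=C(\C)CC/C=C(\C)CCC=C(C)C)cn2C`: 1240 nM

Among the values that are numbers, compound 3 stands lowest at 1240 nM. For the measured compounds named here, the one measured step, a 15-fold lower number from compound 2 to compound 3 (1.17 log units; beyond the scatter), places 3-methylbut-2-en-1-yl on the chain in place of hydrogen. Compound 4 `CO/N=c1\[nH]cnc2c1[n+](C/C=C(\C)CC/C=C(/C)CCC=C(C)C)cn2C` changes only the drawing of one double bond: the two compounds have the same atoms and bonds and differ only in configuration as drawn: 1 of 3 stereo elements differ; a double bond is drawn E in compound 3 and Z in compound 4. Going by the values given here, no measured step tests a change of configuration, so a 15-fold lower number from compound 2 to compound 3 (1.17 log units; beyond the scatter) sets no size for this one and serves only as a distant guide. No step beyond the scatter is expected in this assay, and no firm direction. The estimated step is a 1.1-fold higher number from compound 3 to compound 4 (0.05 log units; within the scatter). For compound 4 the expected value is 1400 nM, with an estimated range of 650 nM to 3000 nM.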

Compound 4, half-maximal inhibitory concentration: 736 nM
Compound 4: middle estimate off by 1.9-fold (0.28 log units), on the high side; low and high end bracket the measured number.
By their numbers in this assay, from the lowest: compounds 4 and 3 (each within the scatter of the next); then compound 2. At a limit, above all of these: compound 1.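

In this assay, the change from E to Z at one chain double bond gives a 1.7-fold lower number from compound 3 to compound 4 (0.23 log units; within the scatter), so this assay does not separate the two geometries at this bond. The chain extension also holds with the Z bond, at a 25-fold lower number from compound 2 to compound 4 (1.40 log units; beyond the scatter). The reading of geometry alone rests on one point: the fact that compounds 3 and 4 differ only in the configuration as drawn.

Still open, from the compounds shown here alone, is whether the other chain double bond tolerates the same change of configuration. Also open, going by these compounds, is what a longer chain, or a chain bearing a carboxylic acid, would give.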